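Trading fluoro for methyl on the benzyl ring

The source may report more compounds than this note shows. Statements on the series, on what has been measured and on what is new or still open speak of the compounds shown alone.

Compound 3 `O=c1cc(Cn2ccnc2)c2ccc(OCc3cccc(F)c3)cc2o1` gives 40 nM in an assay on V79MZh11B1 cells for inhibition of cytochrome P450 11B1, mitochondrial (Homo sapiens), read by HPLC, with a stated time of 25 min; a higher number here means a weaker inhibitor, a lower number a stronger inhibitor. Compound 2 `O=c1cc(Cn2ccnc2)c2ccc(OCc3cc(F)cc(F)c3)cc2o1` gives 45 nM in this assay, and compound 1 `O=c1cc(Cn2ccnc2)c2ccc(OCc3cccc(C(F)(F)F)c3)cc2o1` gives 20 nM; all three values sit within the scatter of one another, so compound 3 stands among them without a clear separation. Compound 4 `Cc1cccc(COc2ccc3c(Cn4ccnc4)cc(=O)oc3c2)c1` differs from compound 3 by methyl in place of fluoro on an aromatic carbon. Going by the values given here, two measured steps touch this position: a 2.0-fold higher number from compound 1 to compound 3 (0.30 log units; within the scatter), and a 1.1-fold lower number from compound 2 to compound 3 (0.05 log units; within the scatter). Neither brings in a methyl, yet both show that swapping the group at this place left this assay within the scatter. For compound 4 the estimated step is a 1.1-fold lower number from compound 3 to compound 4 (0.06 log units; within the scatter), with no direction expected beyond the scatter. Compound 4 is expected at 35 nM, within 15 nM to 90 nM.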

Compound 4, half-maximal inhibitory concentration: 45 nM
Estimate against measurement, compound 4: 1.3-fold (0.11 log units) below, and the stated range covers the measured number.
By their numbers in this assay, from the lowest: compounds 1, 3, 2 and 4 (each within the scatter of the next, the first and the last beyond it).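

In this assay the change to methyl reads as a 1.1-fold higher number from compound 3 to compound 4 (0.05 log units; within the scatter) and the change from the 3,5-difluorophenyl group reads as no change at the digits printed from compound 2 to compound 4 (within the scatter) so methyl cannot be told apart from one or two fluoro groups here. Trifluoromethyl is the one group that separates from methyl, with a 2.3-fold higher number from compound 1 to compound 4 (0.35 log units; beyond the scatter) as the only step at this place that clears the scatter. No evidence shown accounts for that gap.

From the compounds shown here alone, it remains open whether an amine, a carboxylic acid or a longer chain at this place would shift the number beyond the scatter.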